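Swapping the terminal aryl group on a thienopyrimidine urea

The compounds below may be only part of what the source reports. "The series", "measured", "known", "first", "only" and "open" are said of these compounds alone.

Measured so far:
Compound 1 `CCN(CC)CCCNc1nc(-c2ccc(NC(=O)Nc3ccccc3Cl)cc2)nc2c(Cl)c(Cl)sc12` gives 970 nM in a functional assay on MDA-MB-231 cells (Homo sapiens) for cytotoxicity, read by MTT assay, with a stated time of 72 h; on this read-out lower numbers stand for stronger inhibition and higher numbers for weaker inhibition.
Compound 2 `CCN(CC)CCNc1nc(-c2ccc(NC(=O)Nc3ccc(F)cc3)cc2)nc2c(Cl)c(Cl)sc12` gives 1130 nM in this assay.

Among the measured compounds shown here, compound 2 has the highest of the two numbers so far, but its nearest neighbour, compound 1, sits only within the scatter of it, so the two measured values cannot be told apart with confidence. The step under consideration leads from compound 2 to compound 3 `CCN(CC)CCNc1nc(-c2ccc(NC(=O)Nc3ccccc3Cl)cc2)nc2c(Cl)c(Cl)sc12`, and the structural change is 2-chlorophenyl in place of 4-fluorophenyl on an amide-type nitrogen. For the measured compounds named here, no step between two measured compounds is available here, so there is no measured precedent for this exchange. Given that the two measured values lie so close together, the step from compound 2 to compound 3 is expected to be a 1.1-fold lower number from compound 2 to compound 3 (0.05 log units; within the scatter), that is, none beyond the scatter, in either direction. On this basis compound 3 is estimated at 1000 nM in this assay, with a range from 450 nM to 2200 nM.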

Compound 3, half-maximal inhibitory concentration: 1410 nM
Compound 3: middle estimate off by 1.4-fold (0.15 log units), on the low side, within the range that was stated.
By their numbers in this assay, from the lowest: compounds 1, 2 and 3 (each within the scatter of the next).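

In this assay, 2-chlorophenyl in place of 4-fluorophenyl on an amide-type nitrogen gives a 1.2-fold higher number from compound 2 to compound 3 (0.10 log units; within the scatter), so this exchange of terminal aryl groups does not separate the two compounds. Among the compounds shown here, the first measured change in the amine side chain, diethylamino in place of (diethylamino)methyl on a saturated chain carbon with the 2-chlorophenyl group held constant, gives a 1.5-fold higher number from compound 1 to compound 3 (0.16 log units; within the scatter), so neither single change moves the number beyond the scatter. Nothing available here accounts for either step.

The compounds shown leave open whether a pyridine ring in place of the terminal phenyl, or a carboxylic acid or an amine on that phenyl, would give a step beyond the scatter. They also leave open whether a longer chain carrying the diethylamino group, or a cyclic amine such as morpholine in its place, would do so.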